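Methylsulfanyl for methoxy on the hydroxy-bearing chalcone

The source may hold more compounds than are shown below. What is called first, only, known or untested is meant among the compounds shown, and "the series" means these compounds.

Measured compounds:
Compound 1, `COc1cc(OC)c(C(=O)/C=C/c2ccccc2SC)c(OC)c1`: 37%
Compound 2, `COc1cc(O)c(C(=O)/C=C/c2ccccc2OC)c(OC)c1`: "not active" (no number reported)

The two measured compounds share a core and an enone bridge and differ in two places at once. In a functional assay on Huh-7 cells (Homo sapiens), read by fluorescence and BrdU incorporation, with a stated time of 48 h, tested at 10 uM (a higher number here means a weaker effect of the compound at the concentration tested, a lower number a stronger effect), compound 1 gives 37%, a moderate read-out. In this assay compound 2 gives "not active" (no number reported), with no number attached, so compound 2 stands only as a qualitative result and cannot be placed on the same scale as compound 1. For the measured compounds named here, no step between the two measured compounds is available, since they are not single-point neighbours.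

Compound 3, `COc1cc(O)c(C(=O)/C=C/c2ccccc2SC)c(OC)c1`, has not yet been measured in this assay. It differs from compound 2 in one place: methylsulfanyl in place of methoxy on an aromatic carbon. This is the same methylsulfanyl group that compound 1 carries on its second ring, while compound 3 keeps the hydroxy group of compound 2 on the first ring. Going by the values given here, no measured step tells how large an effect this change has in this assay; the comparison between compound 1 and compound 2 mixes two changes and cannot be attributed to either one alone. The expectation is a modest strengthening relative to compound 2, but with wide uncertainty.

For compound 3 in this assay the estimated read-out is 65%, expected to lie between 35% and 100%.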

Compound 3, a percentage reported as activity, at one concentration (the size of the read-out at that concentration, not a potency): 50%
Estimate against measurement, compound 3: 15 percentage points above; the range from low to high includes it.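

With the hydroxy group kept on the first ring, the change from methoxy to methylsulfanyl on the aromatic carbon now separates a compound with a number from one without: in this assay compound 2 is recorded as "not active" (no number reported), while compound 3 gives 50%. Compound 2 has no number on the scale. The size of this step cannot be read. The result also isolates the other difference that had been mixed into the first comparison, since with methylsulfanyl held constant, hydrogen in place of methyl on the aromatic oxygen gives a number 13 percentage points higher from compound 1 to compound 3 (beyond the scatter), a modest weakening that lies beyond the scatter. Nothing shown explains either observation.

On these data alone, what remains open is how the methoxy-bearing compound with all three methoxy groups on the first ring would read in this assay, which would give the methoxy to methylsulfanyl change a numerical size. It is also unknown whether a longer sulfur chain such as ethylsulfanyl, or an amine on the same aromatic carbon, would keep a measurable read-out.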